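Trimming the Aryl Group on the Glycinamide Side Chain

The source may hold more compounds than are shown below. What is called first, only, known or untested is meant among the compounds shown, and "the series" means these compounds.

Going by the values given here, compound 2 `CCOC(=O)C1=C(C)NC(=S)NC1c1cn(C(=O)CNc2ccc([N+](=O)[O-])cc2C)c2ccccc12` gives 3.34 in a physicochemical assay for lipophilicity (on this read-out lower numbers stand for lower lipophilicity and higher numbers for higher lipophilicity), the higher of the two numbers measured so far; its only neighbour, compound 1 `CCOC(=O)C1=C(C)NC(=S)NC1c1cn(C(=O)CNc2ccccc2)c2ccccc12`, gives 2.92. Among the compounds with values here, that pair forms the single measured step, a number 0.42 log units higher from compound 1 to compound 2 (beyond the scatter). Compound 3 `CCOC(=O)C1=C(C)NC(=S)NC1c1cn(C(=O)CNc2cccc([N+](=O)[O-])c2)c2ccccc12` undoes part of that change: 3-nitrophenyl in place of 2-methyl-4-nitrophenyl on an amine nitrogen. Within the data shown here, only the step from compound 1 to compound 2 bears on this move, and it covered the arrival of the whole 2-methyl-4-nitrophenyl group at once, so the present change has no exact precedent. Because compound 1 sits at 2.92 with a plain phenyl, and the 3-nitrophenyl group of compound 3 keeps a nitro substituent but nothing else of the larger group, a modest fall is expected. For compound 3 the expected step in this assay is a number 0.39 log units lower from compound 2 to compound 3 (beyond the scatter). The estimate for compound 3 is 2.95, within 2.55 to 3.35.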

Compound 3, partition coefficient: 2.88
Compound 3: the middle estimate sits 0.07 log units above what was measured; the measured number falls inside the stated range.
By their numbers in this assay, from the lowest: compounds 3 and 1 (each within the scatter of the next); then compound 2.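

In this assay the step of a number 0.46 log units lower from compound 2 to compound 3 (beyond the scatter) shows that the rise seen with 2-methyl-4-nitrophenyl is not kept once that group gives way to 3-nitrophenyl. The step of a number 0.04 log units lower from compound 1 to compound 3 (within the scatter) adds something new: a nitro group on the aromatic ring is not enough on its own to carry the number away from that of the plain phenyl compound, at least when the group is 3-nitrophenyl. Nothing here gives a measured reason for this result.

Compound 2 and compound 3 differ both in the methyl and in where the nitro group sits, so these compounds cannot show which of the two matters. Neighbours bearing 2-methylphenyl or 4-nitrophenyl would separate the two, and a ring carrying an amine or a carboxylic acid in place of nitro remains an open question.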